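Two Limits and an Ethyl Swap

This account rests on a few compounds, and the source may have more. Where it says the series, first, only, none or still open, it means among the compounds named here.

Measured in a functional assay on 786-0 cells (Homo sapiens) for inhibition, read by sulforhodamine B assay, with a stated time of 48 h; on this read-out lower numbers stand for stronger inhibition of growth and higher numbers for weaker inhibition of growth:
- compound 1 `Cc1ccc(C2=NN(c3ccc(S(C)(=O)=O)cc3)C(=O)CC2)cc1`: > 100000 nM, a limit
- compound 2 `Cc1cc(O)ccc1C1=NN(c2ccc(S(C)(=O)=O)cc2)C(=O)CC1`: > 100000 nM, a limit

For compound 2 the reading is > 100000 nM, which is a limit of the assay and not a number. Neither compound has yet given a true number, as this summary shows: the limit of > 100000 nM in this assay, at which 2 of the 2 values shown sit.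

The next compound, compound 3 `CCc1ccc(C2=NN(c3ccc(S(C)(=O)=O)cc3)C(=O)CC2)cc1`, carries 4-ethylphenyl in place of the 4-hydroxy-2-methylphenyl of compound 2, on a carbon with a double bond to nitrogen: 4-ethylphenyl in place of 4-hydroxy-2-methylphenyl on a carbon with a double bond to nitrogen.

Going by the values given here, only one measured step bears on this change, and it is a step that the two limits leave unreadable from compound 1 to compound 2. It therefore offers no size to carry over. Compound 1 carries 4-methylphenyl, the measured group closest in name to 4-ethylphenyl, and its reading of > 100000 nM is also a limit.

With no sign of growth inhibition in either compound, no step beyond the scatter is expected in this assay. The expected step is a number no higher from compound 2 to compound 3 (the limit leaves the size open). For compound 3 the estimated value is 100000 nM, with an expected range from 40000 nM to 200000 nM.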

Compound 3, concentration for total growth inhibition: 80300 nM
Estimate against measurement, compound 3: 1.2-fold (0.10 log units) above; the range from low to high includes it.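

Going by these compounds alone, compound 3 is the first compound here to give a true number in this assay, so this position now yields a step with a readable floor, where the earlier pair gave none. Replacing 4-hydroxy-2-methylphenyl with 4-ethylphenyl on a carbon with a double bond to nitrogen gives an at least 1.2-fold lower number from compound 2 to compound 3 (0.09 log units; that floor lies within the scatter), and lengthening the methyl of compound 1 to ethyl, written as methyl in place of hydrogen on a saturated chain carbon bound to an aromatic carbon, gives an at least 1.2-fold lower number from compound 1 to compound 3 (0.09 log units; that floor lies within the scatter). Each step has a limit at one end, so its full size stays unknown and neither floor establishes a real difference, and most of the readings in this small set still sit at that limit: the limit of > 100000 nM in this assay, at which 2 of the 3 values shown sit.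

The compounds shown leave open whether the true distance from compound 1 or compound 2 to compound 3 is small or large. They also leave open how a longer chain such as propyl, an amine or a carboxylic acid in place of the ethyl of compound 3 would read in this assay.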